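From fluoro to trifluoromethyl on the aromatic ring

The source may hold more compounds than are shown below. What is called first, only, known or untested is meant among the compounds shown, and "the series" means these compounds.

Compound 1 `Fc1ccc(CC2CCC3(CC2)OOCCCOO3)cc1` gives 4.01
Compound 2 `CS(=O)(=O)c1ccc(CC2CCC3(CC2)OOCCCOO3)cc1` gives 2.65
Compound 3 `C=C1COOC2(CCC(Cc3ccc(F)cc3)CC2)OOC1` gives 4.2

In a physicochemical assay for lipophilicity (on this read-out lower numbers stand for lower lipophilicity and higher numbers for higher lipophilicity), compound 3 (4.2) sits within the scatter of compound 1 (4.01). Compound 2 gives 2.65, and compound 3 lies well beyond the scatter on the higher side of it. Compound 4 `C=C1COOC2(CCC(Cc3ccc(C(F)(F)F)cc3)CC2)OOC1` carries trifluoromethyl in place of fluoro on an aromatic carbon and remains unmeasured. Among the measured compounds shown here, only one measured step replaces fluoro on an aromatic carbon: a number 1.36 log units lower from compound 1 to compound 2 (beyond the scatter), a large step. For the measured compounds named here, its entering group is methylsulfonyl, so its size does not carry over, and no trifluoromethyl step has been measured. A moderate rise beyond the scatter is expected instead, with a number 0.50 log units higher from compound 3 to compound 4 (beyond the scatter) as the estimated step. Compound 4 is estimated at 4.7, within an expected range of 4.3 to 5.1.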

Compound 4, partition coefficient: 4.95
Compound 4: middle estimate off by 0.25 log units, on the low side, within the range that was stated.
By their numbers in this assay, from the lowest: compound 2; then compounds 1 and 3 (each within the scatter of the next); then compound 4.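

In this assay the change shows, with a number 0.75 log units higher from compound 3 to compound 4 (beyond the scatter), that replacing fluoro at this position on the aromatic ring can also raise the number. The only earlier replacement of fluoro there, on a different core, went the other way, with a number 1.36 log units lower from compound 1 to compound 2 (beyond the scatter), so across these two steps the direction follows the entering group. No measurement available here explains the size of the new step.

As far as these compounds go, whether an amine, a carboxylic acid or a methoxy group at this position would raise or lower the number remains open. So does whether trifluoromethyl would give a step of similar size on the core of compound 1.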